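Swapping the fluorophenyl on the ketone of compound 1

This account rests on a few compounds, and the source may have more. Where it says the series, first, only, none or still open, it means among the compounds named here.

Compound 1 `Cc1cc(C(=O)c2ccc(F)cc2)ccc1OCC(=O)Nc1nc(-c2ccccc2)cs1`: 37400 nM
Compound 2 `Cc1cc(C(=O)c2ccccc2)cc(C)c1OCC(=O)Nc1nc(-c2ccccc2)cs1`: 22700 nM
Compound 3 `COc1ccc(-c2csc(NC(=O)COc3ccc(C(=O)c4ccc(F)cc4)cc3C)n2)cc1`: 5400 nM

In a functional assay on Ehrlich cells (Mus musculus) for cytotoxicity, read by MTT assay, with a stated time of 48 h (a higher number here means a weaker inhibitor, a lower number a stronger inhibitor), compound 1 gives the highest of the three numbers. Compound 1 and compound 2 lie within the scatter of each other, while the step of a 6.9-fold lower number from compound 1 to compound 3 (0.84 log units; beyond the scatter) is beyond the scatter. Compound 4 `Cc1cc(C(=O)c2ccccc2C)ccc1OCC(=O)Nc1nc(-c2ccccc2)cs1` is made from compound 1 by 2-methylphenyl in place of 4-fluorophenyl on a carbonyl carbon. Among the compounds with values here, none of the measured steps bears on this change: the step from compound 1 to compound 3 sits on a different part of the molecule, and compound 2 differs from compound 1 in more than one place. The data give no guide for this position, so the expected step of a 1.2-fold lower number from compound 1 to compound 4 (0.07 log units; within the scatter) is none beyond the scatter. Compound 4 is therefore estimated at 32000 nM, with a range from 11000 nM to 90000 nM.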

Compound 4, half-maximal inhibitory concentration: 25800 nM
The estimate for compound 4 lay 1.2-fold (0.09 log units) above the measured number; low and high end bracket the measured number.
By their numbers in this assay, from the lowest: compound 3; then compounds 2, 4 and 1 (each within the scatter of the next).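

In this assay, within the data shown here, the first direct reading at this position is a 1.4-fold lower number from compound 1 to compound 4 (0.16 log units; within the scatter), so exchanging 4-fluorophenyl for 2-methylphenyl on the carbonyl carbon leaves the number within the scatter. Two aromatic rings with different substituents are therefore interchangeable here, at least for this pair. Nothing available explains this outcome.

From the compounds shown here alone, whether a group of another kind at this carbonyl carbon, such as an amine or a longer carbon chain, would shift the number remains open. So does whether the methoxy step seen with compound 3 would carry over to the 2-methylphenyl series.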